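The compounds below may be only part of what the source reports. "The series", "measured", "known", "first", "only" and "open" are said of these compounds alone.

Measured so far:
compound 1, `O=C1NCCN1c1ccc(S(=O)(=O)Nc2cccc(Br)c2)cc1` — 87 nM
compound 2, `COc1cc(NS(=O)(=O)c2ccc(N3CCNC3=O)cc2)cc(OC)c1OC` — 19 nM

In a functional assay on K562 cells (Homo sapiens) for antiproliferative activity, read by sulforhodamine B assay, with a stated time of 48 h (a higher number here means a weaker inhibitor, a lower number a stronger inhibitor), compound 1 gives 87 nM, the higher of the two numbers measured. Compound 2 gives 19 nM in this assay, a lower number by a gap that is beyond the usual scatter, so compound 2 is the stronger inhibitor of the two. Going by the values given here, no single-change step between measured compounds is available to guide the next comparison.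

Compound 3, `COc1cccc(NS(=O)(=O)c2ccc(N3CCNC3=O)cc2)c1`, has not yet been measured in this assay. It differs from compound 1 in one place: methoxy in place of bromo on an aromatic carbon. The change sits on an aromatic carbon of a six-membered aromatic ring of carbon only, and the rest of the molecule is kept unchanged. Since compound 2, which carries methoxy groups on the same ring, gives 19 nM, a methoxy group in this position looks compatible with good inhibition, but a single methoxy is not the same as three.

The step from compound 1 to compound 3 is expected to be a 1.5-fold lower number from compound 1 to compound 3 (0.16 log units; within the scatter), a small move toward a lower number or none beyond the scatter. Compound 3 is therefore estimated at 60 nM, within a range from 20 nM to 180 nM.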

Compound 3, half-maximal inhibitory concentration: 230 nM
Estimate against measurement, compound 3: 3.8-fold (0.58 log units) below; measured number outside the range, above it.
By their numbers in this assay, from the lowest: compound 2; then compound 1; then compound 3.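

In this assay, going by these compounds alone, the change from 3-bromophenyl to 3-methoxyphenyl gives the first single-change step, a 2.6-fold higher number from compound 1 to compound 3 (0.42 log units; beyond the scatter), so at this position on the ring bromo goes with the stronger inhibition and methoxy with the weaker, by a modest but real margin. This also changes how compound 2 can be read: compound 3 shows that having a methoxy group on this ring does not by itself go with a low number, and compound 2 differs from compound 3 in more than one place, so its value cannot be credited to any one of its methoxy groups. No measurement available here gives a reason for the loss, and the step stands as an observation only.

Going by these compounds, whether another group in this same place, such as chloro, an amine or a carboxylic acid, would match or improve on bromo remains open. Also open, on these data alone, is which of the added methoxy groups of compound 2 matter, and whether each contributes on its own or only in combination with the others.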